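Swapping Bromine for Iodine at the Same Aromatic Carbon

The compounds below may be only part of what the source reports. "The series", "measured", "known", "first", "only" and "open" are said of these compounds alone.

compound 1 `NCc1ccc2oc(=O)c(C(=O)Oc3cccc(I)c3)cc2c1`: 25.3%
compound 2 `CC(=O)NCc1ccc2oc(=O)c(C(=O)Oc3cccc(F)c3)cc2c1`: 65.6%
compound 3 `CC(=O)NCc1ccc2oc(=O)c(C(=O)Oc3cccc(Br)c3)cc2c1`: 36.9%

In a functional assay on HT-1080 cells (Homo sapiens), read by transwell migration, with a stated time of 24 h, tested at 1 uM (on this read-out lower numbers stand for a stronger effect and higher numbers for a weaker effect at the one concentration tested), compound 3 stands second highest of the three numbers, beyond the scatter from both others: compound 1 lies lower and compound 2 higher. Compound 4 `CC(=O)NCc1ccc2oc(=O)c(C(=O)Oc3cccc(I)c3)cc2c1` differs from compound 3 in one place: iodo in place of bromo on an aromatic carbon. Among the compounds with values here, the one measured step that bears on this is the earlier halogen exchange at the same carbon, which gave a number 28.7 percentage points lower from compound 2 to compound 3 (beyond the scatter). Compound 1 also carries iodo, though it differs elsewhere in the molecule, and its value is lower than that of compound 3. Going one halogen further, a further modest drop is expected, so compound 4 is estimated at 28% (15% to 42%), a step of a number 8.9 percentage points lower from compound 3 to compound 4 (within the scatter).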

Compound 4, a percentage reported as activity, at one concentration (the size of the read-out at that concentration, not a potency): 23.5%
The estimate for compound 4 lay 4.5 percentage points above the measured number; the measured number falls inside the stated range.
By their numbers in this assay, from the lowest: compounds 4 and 1 (each within the scatter of the next); then compound 3; then compound 2.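

In this assay the trend at this aromatic carbon does not stop at bromo: iodo gives a number 13.4 percentage points lower from compound 3 to compound 4 (beyond the scatter) and the full change from fluoro to iodo gives a number 42.1 percentage points lower from compound 2 to compound 4 (beyond the scatter) among these acetylated compounds. With iodo in place, acetyl on the amine nitrogen gives a number 1.8 percentage points lower from compound 1 to compound 4 (within the scatter) and so the free amine and its acetylated form cannot be told apart here. Nothing measured here explains why the numbers move this way.

From the compounds shown here alone, what chloro, methyl or methoxy would give at this carbon remains open. So does whether the free amine and its acetylated form also match when the ring carries bromo or fluoro.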